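The source may hold more compounds than are shown below. What is called first, only, known or untested is meant among the compounds shown, and "the series" means these compounds.

Working notes on the series. In a functional assay on A2780 cells (Homo sapiens) for inhibition, read by sulforhodamine B assay (on this read-out lower numbers stand for stronger inhibition of growth and higher numbers for weaker inhibition of growth), compound 1 `Cc1ccc2[nH]c(-c3ccc(-c4ccc(-c5ccc(N(C)C)cc5)cc4)cc3)nc2c1` gives 2210 nM and compound 2 `COc1ccc(-c2ccc(-c3ccc(-c4nc5cc(C)ccc5[nH]4)cc3)cc2)cc1OC` gives 2130 nM. Compound 3 `Fc1ccc(-c2ccc(-c3ccc(-c4nc5ccccc5[nH]4)cc3)cc2)cc1` gives 48200 nM, the highest number of the three and beyond the scatter from both of the others. Compound 3 differs from compound 1 and compound 2 in more than one place, so that gap cannot be assigned to any single change.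

Compound 4 `Clc1cccc(-c2ccc(-c3ccc(-c4nc5ccccc5[nH]4)cc3)cc2)c1` carries 3-chlorophenyl in place of 4-fluorophenyl, on an aromatic carbon para to a large group: 3-chlorophenyl in place of 4-fluorophenyl on an aromatic carbon. Within the data shown here, only one measured step bears on this, also an exchange of one substituted phenyl for another: 3,4-dimethoxyphenyl in place of 4-(dimethylamino)phenyl gave a 1.0-fold lower number from compound 1 to compound 2 (0.02 log units; within the scatter). That single pair involves different groups and is thin evidence, but it gives no reason to expect a step beyond the scatter in this assay. The expected range still reaches further down than up, since compound 2 stands at 2130 nM with a different terminal group and core. The step expected here is a 1.5-fold lower number from compound 3 to compound 4 (0.18 log units; within the scatter). For compound 4 the estimated value is 32000 nM, with an expected range of 8000 nM to 90000 nM.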

Compound 4, concentration for 50% growth inhibition: 31100 nM
Compound 4: middle estimate off by 1.0-fold (0.01 log units), on the high side; the measured number falls inside the stated range.
By their numbers in this assay, from the lowest: compounds 2 and 1 (each within the scatter of the next); then compounds 4 and 3 (each within the scatter of the next).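

Within this assay, 3-chlorophenyl in place of 4-fluorophenyl, on an aromatic carbon para to a large group, gives a 1.5-fold lower number from compound 3 to compound 4 (0.19 log units; within the scatter), so the read-out does not separate these two terminal groups on the core of compound 3. Among these compounds, the earlier exchange of one substituted phenyl for another, a 1.0-fold lower number from compound 1 to compound 2 (0.02 log units; within the scatter), was read only on the core of compound 1, so this is the first single-place step on the core of compound 3, and it too stays within the scatter. No measurement on hand accounts for either step.

The compounds shown leave open whether the wide gap between compound 3 and the pair of compound 1 and compound 2 belongs to the terminal group, to the core, or to both, and a 4-(dimethylamino)phenyl or 3,4-dimethoxyphenyl group on the core of compound 3 would give the single-place comparison needed. They also leave open whether this position stays as flat with a primary amine or a carboxylic acid on the terminal ring, as only halogen-bearing phenyl groups have been compared on this core.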